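A few compounds are considered here, and "the series" means these few. Any claim that something is new, unique, unknown or untested is made for them only; others in the source may bear on it.

In a functional assay on DLD-1 cells (Homo sapiens) for inhibition, read by MTT assay, with a stated time of 72 h (on this read-out lower numbers stand for stronger inhibition and higher numbers for weaker inhibition), compound 3 `COc1cc(Oc2cccc(Nc3ccccc3)c2)cc(OC)c1CNCc1ccc(F)cc1` gives 2650 nM, the lowest of the two numbers shown. Compound 2 `COc1cc(Oc2cccc(Nc3ccccc3)c2)cc(OC)c1CNCc1ccc(Cl)cc1` gives 3740 nM, and the step of a 1.4-fold lower number from compound 2 to compound 3 (0.15 log units; within the scatter) stays within the scatter. Compound 1 `CCN1CCN(Cc2c(OC)cc(Oc3cccc(Nc4ccccc4)c3)cc2OC)CC1` gives only the assay limit > 20000 nM, not a number. Replacing its 4-ethylpiperazin-1-yl brought an at least 5.3-fold lower number from compound 1 to compound 2 (0.72 log units; beyond the scatter) and an at least 7.5-fold lower number from compound 1 to compound 3 (0.87 log units; beyond the scatter), both beyond the scatter.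

Compound 4 `COc1ccc(CCCNCc2c(OC)cc(Oc3cccc(Nc4ccccc4)c3)cc2OC)cc1` is not yet measured; it differs from compound 3 by 2-(4-methoxyphenyl)ethyl in place of 4-fluorophenyl on a saturated chain carbon bound to an amine nitrogen, so the 4-fluorobenzyl becomes 3-(4-methoxyphenyl)propyl. Going by the values given here, no measured step tests a longer chain or a methoxy group; the only change on this side, fluoro for chloro, stayed within the scatter. Compound 4 is therefore expected to give about 3500 nM, between 1000 nM and 12000 nM. That estimate means an expected 1.3-fold higher number from compound 3 to compound 4 (0.12 log units; within the scatter).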

Compound 4, half-maximal inhibitory concentration: 2540 nM
For compound 4 the middle estimate is 1.4-fold (0.14 log units) above the measured one; the measured number falls inside the stated range.
By their numbers in this assay, from the lowest: compounds 4, 3 and 2 (each within the scatter of the next). At a limit, above all of these: compound 1.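

Swapping 4-fluorophenyl for 2-(4-methoxyphenyl)ethyl gives a 1.0-fold lower number from compound 3 to compound 4 (0.02 log units; within the scatter), and swapping 4-chlorophenyl for the same group gives a 1.5-fold lower number from compound 2 to compound 4 (0.17 log units; within the scatter), so in this assay this position accepts a longer chain with a methoxy group without a change beyond the scatter. Compound 1 gives > 20000 nM, which is a limit of the assay and not a number. Replacing its 4-ethylpiperazin-1-yl with (3-(4-methoxyphenyl)propyl)amino gives an at least 7.8-fold lower number from compound 1 to compound 4 (0.89 log units; beyond the scatter), so the longer chain keeps the gain seen with the benzyl groups.

Chain length and the methoxy group change together here, so neither can be judged alone. As far as these compounds go, how a chain ending in a carboxylic acid or a plain alkyl chain without the aromatic ring would read remains open.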